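A few compounds are considered here, and "the series" means these few. Any claim that something is new, unique, unknown or untested is made for them only; others in the source may bear on it.

Working notes on the series. Of the compounds shown here, two have been measured so far in an ADME assay on HepG2 cells (Homo sapiens) for cytotoxicity, read by MTT assay, with a stated time of 24 h, tested at 1 uM; on this read-out lower numbers stand for a stronger effect and higher numbers for a weaker effect at the one concentration tested. Compound 1, `COc1cc(C2=NNC(c3ccc(Cl)cc3)C2)ccc1O`, carries a hydrogen on the ring amine nitrogen of the shared core; in this assay compound 1 gives 99%. Compound 2, `COc1cc(C2=NN(C(=O)c3ccccc3)C(c3ccc(Cl)cc3)C2)ccc1O`, carries a benzoyl group there instead; in this assay compound 2 gives 90%. The single step between them, a number 9 percentage points lower from compound 1 to compound 2 (within the scatter), does not reach beyond the scatter, so compound 2 and compound 1 cannot be told apart on these numbers, and compound 2 stands at a value that is indistinguishable from the only other one shown.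

Compound 3, `COc1cc(C2=NN(S(=O)(=O)c3ccc(C)cc3)C(c3ccc(Cl)cc3)C2)ccc1O`, is not yet measured. Relative to compound 2 the change is (4-methylphenyl)sulfonyl in place of benzoyl on an amine nitrogen in a ring. For the measured compounds named here, the only measured step that touches the same ring nitrogen is the one from compound 1 to compound 2, and it was within the scatter; no step exchanges one acyl-type substituent for a sulfonyl one, so the expectation rests on the two values alone. On that basis no step beyond the scatter is expected in this assay, and the step from compound 2 to compound 3 is estimated at no change at the digits printed from compound 2 to compound 3 (within the scatter). Compound 3 is therefore expected to give about 90% in this assay, with a range from 78% to 100%.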

Compound 3, a percentage reported as activity, at one concentration (the size of the read-out at that concentration, not a potency): 91.2%
Estimate against measurement, compound 3: 1.2 percentage points below, within the range that was stated.
By their numbers in this assay, from the lowest: compounds 2, 3 and 1 (each within the scatter of the next).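

In this assay, (4-methylphenyl)sulfonyl in place of benzoyl on the amine nitrogen in the ring gives a number 1.2 percentage points higher from compound 2 to compound 3 (within the scatter) and, set against the hydrogen of compound 1, the same group gives a number 7.8 percentage points lower from compound 1 to compound 3 (within the scatter) on this read-out. The earlier pair showed only a single substituent at this nitrogen; there are now two, joined through a carbonyl in one case and a sulfonyl in the other, and compounds 1, 2 and 3 cannot be told apart on these numbers, even with the larger entering group and its additional hydrogen-bond acceptor. No measurement at hand accounts for this outcome.

The groups shown at this nitrogen all carry a six-membered aromatic ring of carbon and no net charge, so it remains open whether a substituent with an amine, a carboxylic acid or a longer chain in place of that ring would also stay within the scatter of these compounds. With one concentration and one cell line shown, it also remains open whether compounds 1, 2 and 3 would separate at other concentrations or in other cells.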